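The source may report more compounds than this note shows. Statements on the series, on what has been measured and on what is new or still open speak of the compounds shown alone.

Compound 2 `CC(=O)Nc1cccc(C2CCN(CCCn3c(-c4ccccc4C(F)(F)F)nc4ccccc43)CC2)c1` stands at the higher of the two numbers recorded so far in an assay for displacement of a labelled ligand from melanin-concentrating hormone receptor 1 (Homo sapiens), read by fluorescence (a higher number here means a weaker inhibitor, a lower number a stronger inhibitor), where compound 2 gives 50 nM. Among the compounds with values here, compound 1 `CC(=O)Nc1cccc(C2CCN(CCCn3c(-c4ccccc4Cl)nc4ccccc43)CC2)c1` gives 10 nM in this assay, and the only measured step, a 5.0-fold higher number from compound 1 to compound 2 (0.70 log units; beyond the scatter), separates the two. Compound 3 `CC(=O)Nc1cccc(C2CCN(CCCn3c(-c4cccc(C(F)(F)F)c4)nc4ccccc43)CC2)c1` keeps every atom of compound 2 and differs only in where the trifluoromethyl sits: 3-(trifluoromethyl)phenyl in place of 2-(trifluoromethyl)phenyl on an aromatic carbon. Within the data shown here, no measured step in this set moves a group from one ring position to another; the step from compound 1 to compound 2 swaps the group itself, so it bears on compound 3 only indirectly. With so little to lean on, compound 3 is expected to give a number near that of compound 2, and the expected step of a 1.2-fold higher number from compound 2 to compound 3 (0.08 log units; within the scatter) is set within the scatter. The estimate for compound 3 is therefore 60 nM, with a range from 15 nM to 300 nM in this assay.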

Compound 3, half-maximal inhibitory concentration: 30 nM
For compound 3 the middle estimate is 2.0-fold (0.30 log units) above the measured one; low and high end bracket the measured number.
By their numbers in this assay, from the lowest: compound 1; then compounds 3 and 2 (each within the scatter of the next).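

In this assay the change from 2-(trifluoromethyl)phenyl to 3-(trifluoromethyl)phenyl gives a 1.7-fold lower number from compound 2 to compound 3 (0.22 log units; within the scatter) and so, on this aromatic carbon between two ring nitrogen atoms, the two placements of the trifluoromethyl cannot be told apart. The other new step, a 3.0-fold higher number from compound 1 to compound 3 (0.48 log units; beyond the scatter) with 3-(trifluoromethyl)phenyl in place of 2-chlorophenyl, shows that the gap to compound 1 remains beyond the scatter whichever of the two placements is used. Nothing available accounts for either step.

On these data alone, it remains open whether 3-chlorophenyl would give a number close to that of compound 1, which would separate the effect of the group from that of its placement. Also open, as far as these compounds go, is how a plain phenyl, or a phenyl carrying a methoxy or a nitrile, would compare on this carbon.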